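Early benzyl ether ureas: moving from compound 3 to compound 4

This account rests on a few compounds, and the source may have more. Where it says the series, first, only, none or still open, it means among the compounds named here.

Measured so far in a functional assay on GBM1 cells (Homo sapiens) for antiproliferative activity, read by WST assay, with a stated time of 72 h; a lower number here means a stronger inhibitor, a higher number a weaker inhibitor:
- compound 1 `O=C(Nc1ccccc1F)Nc1cc2ncncc2cc1OCc1ccccc1` gives 6100 nM
- compound 2 `O=C(Nc1cccc(F)c1)Nc1cc2ncncc2cc1OCc1cccc(Cl)c1` gives 3700 nM
- compound 3 `O=C(Nc1ccccc1F)Nc1cc2ncncc2cc1OCc1ccccc1F` gives 4200 nM

Compound 3, at 4200 nM, lies within the scatter of both other compounds, so the three values are not separated in this assay. Compound 4 `O=C(Nc1ccccc1F)Nc1cc2ncncc2cc1OCc1cccc(Cl)c1` differs from compound 3 as follows: 3-chlorophenyl in place of 2-fluorophenyl on a saturated chain carbon bound to an oxygen on an aromatic ring. In words, this places 3-chlorophenyl in place of 2-fluorophenyl on a saturated chain carbon bound to an oxygen on an aromatic ring.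

Going by the values given here, the only measured step in this group is a 1.5-fold lower number from compound 1 to compound 3 (0.16 log units; within the scatter), with fluoro in place of hydrogen on an aromatic carbon. Compound 2 also carries 3-chlorobenzyl and gives 3700 nM, but it differs from compound 4 elsewhere as well. The data therefore offer no ground for expecting a real change. The expected step is a 1.1-fold lower number from compound 3 to compound 4 (0.03 log units; within the scatter), which is no shift beyond the scatter. For compound 4 the estimated value is 3900 nM, with an expected range from 1800 nM to 8000 nM.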

Compound 4, half-maximal inhibitory concentration: 4200 nM
Beside the measured number, compound 4's estimate is 1.1-fold (0.03 log units) below it; low and high end bracket the measured number.
By their numbers in this assay, from the lowest: compounds 2, 3, 4 and 1 (each within the scatter of the next).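

In this assay, 3-chlorophenyl in place of 2-fluorophenyl on the saturated chain carbon bound to an oxygen on an aromatic ring gives no change at the digits printed from compound 3 to compound 4 (within the scatter) here, so this exchange of both halogen and ring position does not separate the two compounds. With 3-chlorobenzyl held constant, 2-fluorophenyl in place of 3-fluorophenyl on the amide-type nitrogen gives a 1.1-fold higher number from compound 2 to compound 4 (0.06 log units; within the scatter) in this pair. A single added chloro group gives a 1.5-fold lower number from compound 1 to compound 4 (0.16 log units; within the scatter) as its step, so this addition is likewise not resolved.

As far as these compounds go, whether an amine, a carboxylic acid or a longer chain in place of 3-chlorophenyl would give a step beyond the scatter remains open. No supporting data bear on these results.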